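The compounds below may be only part of what the source reports. "The series", "measured", "known", "first", "only" and "open" are said of these compounds alone.

Compound 1 `CN1CC[C@H](c2ccc(Cl)cc2)[C@@H](C(=O)OC(C)(C)C)C1` gives 318 nM in an assay on striatum with sodium-dependent dopamine transporter (Rattus norvegicus) as the target; on this read-out higher numbers stand for weaker inhibition and lower numbers for stronger inhibition; compound 2 `CN1CC[C@H](c2ccc(Cl)cc2)[C@@H](CC(=O)N(C)C)C1` gives 16 nM.

Compound 1 stands highest of the two numbers, with compound 2 the nearest at a 20-fold lower number from compound 1 to compound 2 (1.30 log units; beyond the scatter). Compound 3 `CN1CC[C@H](c2ccc(Cl)cc2)[C@@H](CCCO)C1` differs from compound 1 by 3-hydroxypropyl in place of tert-butoxycarbonyl on a saturated ring carbon. Going by the values given here, the one step that bears on this is the exchange of the same tert-butoxycarbonyl for (dimethylcarbamoyl)methyl, which gave a 20-fold lower number from compound 1 to compound 2 (1.30 log units; beyond the scatter). Because that replacement at the same saturated ring carbon gave a 20-fold lower number from compound 1 to compound 2 (1.30 log units; beyond the scatter), a lower number is expected for compound 3 too, though the 3-hydroxypropyl group is not the same, so a smaller step is estimated: a 4.0-fold lower number from compound 1 to compound 3 (0.60 log units; beyond the scatter). Compound 3 is therefore estimated at 80 nM, with a range from 25 nM to 250 nM.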

Compound 3, inhibition constant: 16 nM
Estimate against measurement, compound 3: 5.0-fold (0.70 log units) above, and the stated range ends above it.
By their numbers in this assay, from the lowest: compounds 2 and 3 (each within the scatter of the next); then compound 1.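

With a 20-fold lower number from compound 1 to compound 3 (1.30 log units; beyond the scatter) in this assay as a second large step at this saturated ring carbon, the move away from tert-butoxycarbonyl no longer rests on (dimethylcarbamoyl)methyl alone. The two replacements also stand level, with no change at the digits printed from compound 2 to compound 3 (within the scatter) for 2-hydroxyethyl in place of dimethylcarbamoyl on the saturated chain carbon, so in these compounds an amide end and a hydroxyl end give the same number. As far as these compounds go, it remains open whether an amine or a carboxylic acid at the end of this chain, or a longer chain, would keep that number. Nothing measured here explains either step.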